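The compounds below may be only part of what the source reports. "The series", "measured", "known", "first", "only" and "open" are said of these compounds alone.

Measured compounds:
compound 1, `CC1=C(/C=C/C(=O)/C=C/c2cccc(C(F)(F)F)c2)C(C)(C)CCC1`: 2800 nM
compound 2, `CC1=C(/C=C/C(=O)/C=C/c2cc(C(F)(F)F)cc(C(F)(F)F)c2)C(C)(C)CCC1`: 8700 nM
compound 3, `CC1=C(/C=C/C(=O)/C=C/c2ccccc2)C(C)(C)CCC1O`: 5800 nM

These three compounds were tested in a functional assay on LNCaP cells (Homo sapiens) for cytotoxicity, read by MTT assay, with a stated time of 72 h; on this read-out higher numbers stand for weaker inhibition and lower numbers for stronger inhibition. Compound 1 and compound 2 share one core and differ by trifluoromethyl in place of hydrogen on an aromatic carbon; this change gave a 3.1-fold higher number from compound 1 to compound 2 (0.49 log units; beyond the scatter). Compound 3 sits on a different core, and the difference between the two cores is not broken down here. Compound 4, `CC1=C(/C=C/C(=O)/C=C/c2ccc(C(F)(F)F)cc2)C(C)(C)CCC1O`, is drawn from compound 3 by trifluoromethyl in place of hydrogen on an aromatic carbon. For the measured compounds named here, it is the same kind of change as the one from compound 1 to compound 2, but not the same: in the earlier pair the entering group sits meta to a large group and meta to a trifluoromethyl group, whereas in compound 4 it sits para to a large group and no second trifluoromethyl group is present. The step in this assay from compound 3 to compound 4 is expected to be a 1.6-fold higher number from compound 3 to compound 4 (0.19 log units; within the scatter), a smaller shift than the earlier one, because a 3.1-fold higher number from compound 1 to compound 2 (0.49 log units; beyond the scatter) was measured at a different place on a different core. Compound 4 is therefore estimated at 9000 nM, with a plausible range from 3500 nM to 25000 nM.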

Compound 4, half-maximal inhibitory concentration: 3000 nM
Compound 4: the middle estimate sits 3.0-fold (0.48 log units) above what was measured; measured number below the stated range.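

On the core of compound 3, trifluoromethyl in place of hydrogen gave a 1.9-fold lower number from compound 3 to compound 4 (0.29 log units; within the scatter), so no real shift can be claimed for this pair. Set beside the earlier pair, the same kind of change did not carry over from one core to the other in this assay: the same change on two cores in this assay, a 3.1-fold higher number (0.49 log units; beyond the scatter) from compound 1 to compound 2 and a 1.9-fold lower number (0.29 log units; within the scatter) from compound 3 to compound 4, 6.0-fold (0.78 log units) apart, beyond the scatter of two such steps

This does not show what separates the two steps: the pairs differ in their core, but also in where the entering group sits and in whether a second trifluoromethyl group is present, and a single pair on each core supports no rule for the series.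

The compounds shown leave open whether the two cores would still part this way with the entering group at the same place on the ring. They also leave open how an amine or a carboxylic acid at that place would compare with trifluoromethyl on either core.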